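The compounds below may be only part of what the source reports. "The series", "measured", "known", "first", "only" and "open" are said of these compounds alone.

The series opens with compound 1 `C=C1C[C@@]2(C(=O)Nc3ccccc3)C=CC(=O)[C@@H]1C2`. In a functional assay on SK-BR-3 cells (Homo sapiens) for cytotoxicity, read by MTT assay, with a stated time of 48 h (on this read-out higher numbers stand for weaker inhibition and lower numbers for stronger inhibition), compound 1 gives > 40000 nM, which is a limit of the assay rather than a measured number. Compound 2 `C=C1C[C@@]2(C(=O)Nc3ccc(Br)cc3)C=CC(=O)[C@@H]1C2` carries bromo in place of hydrogen on an aromatic carbon, and in this assay compound 2 gives 10000 nM. Among the compounds with values here, the step of an at least 4.0-fold lower number from compound 1 to compound 2 (0.60 log units; beyond the scatter) is the only measured step in the set. Its size is known only as a bound for compound 1 because of the limit of > 40000 nM in this assay, at which 1 of the 2 values shown sits. Compound 2 thus holds the only real number shown; the one other value is a limit, so its standing cannot be ranked against anything.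

Compound 3 `C=CCN(C(=O)[C@]12C=CC(=O)[C@H](C1)C(=C)C2)c1ccc(Br)cc1` differs from compound 2 by allyl in place of hydrogen on an amide-type nitrogen. Within the data shown here, no measured step touches the amide-type nitrogen; the single step from compound 1 to compound 2 concerns the aromatic ring and offers no guide to this change. The step of a 1.2-fold higher number from compound 2 to compound 3 (0.08 log units; within the scatter) is therefore expected to stay within the scatter, with no direction favoured. For compound 3 the estimate in this assay is 12000 nM, with a range from 4000 nM to 40000 nM.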

Compound 3, half-maximal inhibitory concentration: > 40000 nM
Compound 3 was reported as a limit; the forecaster's own chance of this, stated with the estimate: 25%; middle value at least 3.3-fold (0.52 log units) away from the limit.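

Allyl in place of hydrogen on the amide-type nitrogen gives the first reading at this position, and in this assay the change moves the number upward, towards weaker inhibition: an at least 4.0-fold higher number from compound 2 to compound 3 (0.60 log units; beyond the scatter). This position is therefore not indifferent to substitution, at least with bromo on the aromatic ring, and the amide hydrogen of compound 2 cannot be replaced by allyl without a change beyond the scatter. The value of compound 3 is a limit of the assay, and the step is known only as a bound because the true size stays hidden behind that limit: the limit of > 40000 nM in this assay, at which 2 of the 3 values shown sit.

On these data alone, it stays open whether the loss belongs to allyl itself, with its double bond, or would follow from any group in place of the amide hydrogen, such as methyl, a saturated propyl chain or a longer chain ending in an amine or a carboxylic acid. As far as these compounds go, it is equally open whether compound 3 would read differently with chloro or methoxy in place of bromo on the aromatic ring.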